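Acetyl on the ring nitrogen of compound 2

A few compounds are considered here, and "the series" means these few. Any claim that something is new, unique, unknown or untested is made for them only; others in the source may bear on it.

Of the compounds shown here, two of this small set have numbers so far in a functional assay on HCT-116 cells (Homo sapiens) for cytotoxicity; on this read-out higher numbers stand for an effect only at larger amounts of compound and lower numbers for an effect already at smaller amounts. Compound 1 (`COc1ccc(S(=O)(=O)Nc2ccc(C(=O)CSC(C)=O)cc2)cc1`) gives 500 nM there. Compound 2 (`CC(=O)SCC(=O)c1ccc(NS(=O)(=O)c2ccc3c(c2)NCC3)cc1`) gives 3300 nM, the higher of the two numbers, and the gap to compound 1 lies beyond the usual scatter of repeated measurements.

Compound 3 (`CC(=O)SCC(=O)c1ccc(NS(=O)(=O)c2ccc3c(c2)N(C(C)=O)CC3)cc1`) departs from compound 2 in one place. It carries acetyl in place of hydrogen on a nitrogen on an aromatic ring in a ring. Among the measured compounds shown here, no measured pair shows what such a change does in this assay, so any forecast here is tentative. The only guide is that compound 1 (500 nM) shows a lower number is reachable among these compounds, and that alone favours a move downward rather than upward.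

The expected move in this assay is modest, an estimated 2.4-fold lower number from compound 2 to compound 3 (0.37 log units; beyond the scatter) toward a lower number, and it may not clear the scatter by much. The estimated value for compound 3 is 1400 nM (expected range 400 nM to 4500 nM).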

Compound 3, half-maximal effective concentration: 4600 nM
Compound 3: the middle estimate sits 3.3-fold (0.52 log units) below what was measured; measured number above the stated range.
By their numbers in this assay, from the lowest: compound 1; then compounds 2 and 3 (each within the scatter of the next).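

In this assay, acetyl in place of hydrogen on the nitrogen of the five-membered non-aromatic ring gives a 1.4-fold higher number from compound 2 to compound 3 (0.14 log units; within the scatter), a step that stays within the usual scatter of repeated measurements. Among the compounds shown here, this is the first measured change at this position, and it shows that the nitrogen can carry acetyl, with its 3 heavy atoms and no ring, without any shift in the number that can be told apart from scatter. Nothing measured here gives a reason for this result.

The compounds shown leave open whether this tolerance belongs to acetyl alone or extends to other groups on the same nitrogen, such as a methyl group, a longer acyl chain or a chain ending in a carboxylic acid or an amine. One step within the scatter also cannot show whether a group at this position can move the number in either direction, so the sensitivity of this nitrogen to substitution remains an open question.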